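Swapping the aryl group at the end of the side chain

The source may hold more compounds than are shown below. What is called first, only, known or untested is meant among the compounds shown, and "the series" means these compounds.

Compound 1 `COc1ccc(OC)c(/C=C/C(=O)Nc2cc3c(Nc4ccc(F)c(Cl)c4)ncnc3cc2O[C@H]2CCOC2)c1` gives 36300 nM in a functional assay on MCF7 cells (Homo sapiens) for cytotoxicity, read by MTT assay, with a stated time of 72 h (a lower number here means a stronger inhibitor, a higher number a weaker inhibitor), the highest of the three numbers seen so far, though none of the three is separated from another by more than the usual scatter. Compound 2 `COc1cc(/C=C/C(=O)Nc2cc3c(Nc4ccc(F)c(Cl)c4)ncnc3cc2O[C@H]2CCOC2)cc(OC)c1O` gives 30500 nM and compound 3 `O=C(/C=C/c1ccc(F)cc1Cl)Nc1cc2c(Nc3ccc(F)c(Cl)c3)ncnc2cc1O[C@H]1CCOC1` gives 26200 nM. The two steps from compound 1 are a 1.2-fold lower number from compound 1 to compound 2 (0.08 log units; within the scatter) and a 1.4-fold lower number from compound 1 to compound 3 (0.14 log units; within the scatter), so exchanging the ring at this place has so far left the number essentially where it was. Compound 4 `COc1ccc(/C=C/C(=O)Nc2cc3c(Nc4ccc(F)c(Cl)c4)ncnc3cc2O[C@H]2CCOC2)cc1` differs from compound 1 by 4-methoxyphenyl in place of 2,5-dimethoxyphenyl on a double-bonded chain carbon bound to a double-bonded chain carbon. Both measured steps concern the same place and neither moved the number beyond the scatter, so compound 4 is expected to show a 1.1-fold lower number from compound 1 to compound 4 (0.05 log units; within the scatter), no shift beyond the scatter. Compound 4 is therefore estimated at 32000 nM, between 15000 nM and 65000 nM.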

Compound 4, half-maximal inhibitory concentration: 5070 nM
For compound 4 the middle estimate is 6.3-fold (0.80 log units) above the measured one; measured number outside the range, below it.
By their numbers in this assay, from the lowest: compound 4; then compounds 3, 2 and 1 (each within the scatter of the next).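

This position is not indifferent: the aryl group can move the number, as a 7.2-fold lower number from compound 1 to compound 4 (0.85 log units; beyond the scatter) and a 6.0-fold lower number from compound 2 to compound 4 (0.78 log units; beyond the scatter) and also a 5.2-fold lower number from compound 3 to compound 4 (0.71 log units; beyond the scatter) all show in this assay for one group alone. Compound 1, compound 2 and compound 3 remain within the scatter of one another, so 4-methoxyphenyl stands apart from all three other rings. Nothing available explains this difference. From the compounds shown here alone, whether it belongs to the methoxy group itself stays open: a plain phenyl ring, or an ethoxy group in place of the methoxy group, would test that.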